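The source may hold more compounds than are shown below. What is called first, only, known or untested is meant among the compounds shown, and "the series" means these compounds.

Compound 1 `CC(C)(C)c1cc(NC(=O)Nc2ccc(Cl)cc2)n(-c2ccc(C(F)(F)F)cc2)n1` gives 0.7 degrees C in an assay on isolated protein for inhibition of STE20-like serine/threonine-protein kinase (Homo sapiens), read by thermal shift assay, tested at 10 uM; a lower number here means that the compound stabilises the target less, a higher number that the compound stabilises the target more against heat. Compound 2 `CC(C)(C)c1cc(NC(=O)Nc2ccc(Cl)cc2)n(-c2ccc(C#N)cc2)n1` gives 1.6 degrees C. Compound 3 `CC(C)(C)c1cc(NC(=O)Nc2ccc(Cl)cc2)n(-c2ccc(NC(=O)C3CC3)cc2)n1` gives 4.1 degrees C.

Compound 3 stands highest of the three numbers. Its lead over the others is real: a number 2.5 degrees C higher from compound 2 to compound 3 (beyond the scatter) and a number 3.4 degrees C higher from compound 1 to compound 3 (beyond the scatter), both beyond the usual scatter, whereas the gap a number 0.90 degrees C higher from compound 1 to compound 2 (within the scatter) is within it.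

Compound 4 `CC(C)(C)c1cc(NC(=O)Nc2ccc(Cl)cc2)n(-c2ccc(NS(C)(=O)=O)cc2)n1` differs from compound 3 in one place: methylsulfonyl in place of cyclopropylcarbonyl on a nitrogen on an aromatic ring. Among the compounds with values here, no measured step changes a group on this nitrogen, so none bears directly on the move. The two steps that do bear on it indirectly, from compound 1 and from compound 2 to compound 3, show that bringing in the (cyclopropylcarbonyl)amino group raised the number modestly; compound 4 keeps the amino linkage and exchanges only what sits on it. The step of a number 1.1 degrees C lower from compound 3 to compound 4 (beyond the scatter) is therefore expected to be small, a slight fall at most, within or just beyond the scatter. Compound 4 is estimated at 3 degrees C, with a range from 1.5 degrees C to 4.5 degrees C.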

Compound 4, shift of the target's melting temperature: 7.3 degrees C
Compound 4: the middle estimate sits 4.3 degrees C below what was measured; measured number above the stated range.
By their numbers in this assay, from the lowest: compounds 1 and 2 (each within the scatter of the next); then compound 3; then compound 4.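

In this assay, exchanging cyclopropylcarbonyl for methylsulfonyl on a nitrogen on an aromatic ring gives a number 3.2 degrees C higher from compound 3 to compound 4 (beyond the scatter), so the group on this nitrogen matters, even with the linkage to the aromatic ring kept. Methanesulfonamido also gives a number 5.7 degrees C higher from compound 2 to compound 4 (beyond the scatter) in place of cyano and a number 6.6 degrees C higher from compound 1 to compound 4 (beyond the scatter) in place of trifluoromethyl, so the rise seen earlier with (cyclopropylcarbonyl)amino was not the limit for this position. Nothing available explains why methylsulfonyl outdoes cyclopropylcarbonyl here.

As far as these compounds go, it remains open whether the rise depends on the methyl of methylsulfonyl, which an ethylsulfonyl or phenylsulfonyl group on the same nitrogen would test. From the compounds shown here alone, it also remains open whether the hydrogen on that nitrogen matters, which a methyl group in its place would test.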